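Isoquinoline in place of hydroxytetralin on the urea nitrogen

The compounds below may be only part of what the source reports. "The series", "measured", "known", "first", "only" and "open" are said of these compounds alone.

Among the compounds with values here, compound 3 `CN(C)C1(Cc2ccccc2)CCN(c2cc(C(F)(F)F)ccc2CNC(=O)Nc2cccc3c2CC(O)CC3)CC1` gives 0.95 nM in an assay on CHO cells for displacement of a labelled ligand from transient receptor potential cation channel subfamily V member 1 (Homo sapiens), read by scintillation counting, with a stated time of 60 min (a lower number here means a stronger inhibitor, a higher number a weaker inhibitor), the lowest of the three numbers measured so far. Compound 1 `CC(C(=O)NCc1ccc(C(F)(F)F)cc1N1CCC(Cc2ccccc2)(N(C)C)CC1)c1ccc(NS(C)(=O)=O)c(F)c1` gives 3.79 nM in this assay, and compound 2 `CN(C)C1(Cc2ccccc2)CCN(c2cc(C(F)(F)F)ccc2CNC(=O)Nc2ccc(CNS(C)(=O)=O)c(F)c2)CC1` gives 16.4 nM in this assay; both gaps to compound 3 lie beyond the scatter. Compound 4 `CN(C)C1(Cc2ccccc2)CCN(c2cc(C(F)(F)F)ccc2CNC(=O)Nc2cccc3cnccc23)CC1` has not yet been measured. It differs from compound 3 by isoquinolin-5-yl in place of 3-hydroxy-1,2,3,4-tetrahydronaphthalen-5-yl on an amide-type nitrogen. Within the data shown here, no measured pair shows this kind of change, so the expectation rests on the structural change alone and is uncertain. A modest weakening is expected, a step of a 3.2-fold higher number from compound 3 to compound 4 (0.50 log units; beyond the scatter) that could still fall within the scatter. Compound 4 is therefore estimated to give 3 nM in this assay, within a range from 1 nM to 10 nM.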

Compound 4, inhibition constant: 0.67 nM
For compound 4 the middle estimate is 4.5-fold (0.65 log units) above the measured one; measured number below the stated range.
By their numbers in this assay, from the lowest: compounds 4 and 3 (each within the scatter of the next); then compound 1; then compound 2.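

In this assay, this amide-type nitrogen accepts isoquinolin-5-yl in place of 3-hydroxy-1,2,3,4-tetrahydronaphthalen-5-yl with no change beyond the scatter (a 1.4-fold lower number from compound 3 to compound 4 (0.15 log units; within the scatter)). The hydrogen-bond donor of the leaving group is therefore not needed here, since compound 4, which has none in that group, gives 0.67 nM. No evidence on why the exchange leaves the number within the scatter is available.

As far as these compounds go, whether the ring nitrogen of isoquinolin-5-yl matters remains open, and a plain naphthalen-1-yl group would test this. Also open, from the compounds shown here alone, is whether an amine on that ring would keep the number.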